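This account rests on a few compounds, and the source may have more. Where it says the series, first, only, none or still open, it means among the compounds named here.

Of the compounds shown here, three built on a shared core have been measured, and a fourth awaits its number. In a functional assay on SK-MEL-28 cells (Homo sapiens) for inhibition, read by MTT assay, with a stated time of 72 h (a higher number here means a weaker inhibitor, a lower number a stronger inhibitor), compound 1 (`CCC(=O)O[C@@H](/C(C)=C/[C@@H](C)c1oc(CC)c(C)c(=O)c1C)[C@H](C)[C@@H](OC(=O)CC(C)C)[C@@H](C)c1oc([C@@H](C)[C@@H](O)CC)c(C)c(=O)c1C`) gives 25000 nM, compound 2 (`CCc1oc([C@H](C)/C=C(\C)[C@H](OC(C)=O)[C@H](C)[C@@H](OC(=O)CC(C)C)[C@@H](C)c2oc([C@@H](C)[C@H](CC)OC(C)=O)c(C)c(=O)c2C)c(C)c(=O)c1C`) gives 33000 nM and compound 3 (`CCC(=O)O[C@@H](/C(C)=C/[C@@H](C)c1oc(CC)c(C)c(=O)c1C)[C@H](C)[C@@H](OC(=O)CC(C)C)[C@@H](C)c1oc([C@@H](C)[C@H](CC)OC(C)=O)c(C)c(=O)c1C`) gives 7000 nM. Compound 2 and compound 1 lie within the usual scatter of each other at the weak end of this small set, while compound 3 stands clearly apart, with a 4.7-fold lower number from compound 2 to compound 3 (0.67 log units; beyond the scatter).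

Compound 4 (`CCc1oc([C@H](C)/C=C(\C)[C@H](OC(C)=O)[C@H](C)[C@@H](OC(=O)CC(C)C)[C@@H](C)c2oc([C@@H](C)[C@@H](O)CC)c(C)c(=O)c2C)c(C)c(=O)c1C`) is compound 2 with hydrogen in place of acetyl on an oxygen on a saturated carbon. The closest evidence is the same exchange in the opposite sense, seen as a 3.6-fold lower number from compound 1 to compound 3 (0.55 log units; beyond the scatter). Removing the acetyl should therefore raise the number in this assay. The other step, a 4.7-fold lower number from compound 2 to compound 3 (0.67 log units; beyond the scatter), is a different change, methyl in place of hydrogen on a saturated chain carbon bound to a carbonyl carbon, and it does not test the acetyl directly. Among the measured compounds shown here, with only one pair as a guide, the size remains uncertain. The expected change is a 2.1-fold higher number from compound 2 to compound 4 (0.33 log units; beyond the scatter), a modest weakening beyond the scatter. The estimated value for compound 4 is 70000 nM, with an expected range from 25000 nM to 150000 nM.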

Compound 4, half-maximal inhibitory concentration: 25000 nM
Compound 4: middle estimate off by 2.8-fold (0.45 log units), on the high side, and the stated range covers the measured number.
By their numbers in this assay, from the lowest: compound 3; then compounds 1, 4 and 2 (each within the scatter of the next).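

In this assay, the acetyl on the oxygen on a saturated carbon proves to matter on only one of the two cores, for the new step reads a 1.3-fold lower number from compound 2 to compound 4 (0.12 log units; within the scatter), which sets acetoxy to hydroxy on the core of compound 2 apart from the same exchange on the core of compound 1: the same change on two cores in this assay, a 3.6-fold lower number (0.55 log units; beyond the scatter) from compound 1 to compound 3 and a 1.3-fold higher number (0.12 log units; within the scatter) from compound 4 to compound 2, 4.7-fold (0.67 log units) apart, beyond the scatter of two such steps The second exchange, hydrogen in place of methyl on a saturated chain carbon bound to a carbonyl carbon, likewise reads no change at the digits printed from compound 1 to compound 4 (within the scatter), and so it too depends on what the rest of the molecule carries: the same change on two cores in this assay, a 4.7-fold lower number (0.67 log units; beyond the scatter) from compound 2 to compound 3 and no change at the digits printed (within the scatter) from compound 4 to compound 1, 4.7-fold (0.67 log units) apart, beyond the scatter of two such steps The two exchanges therefore do not simply add up, since among these compounds the lower number of compound 3 appears only where the acetyl and that methyl occur together.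

As far as these compounds go, what remains open is whether this dependence extends beyond the acetyl, for instance to a longer chain such as butanoyl on the same oxygen. From the compounds shown here alone, it is equally open how an amine in place of the hydroxy would read on either core.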